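Dichlorophenyl in Place of Bromophenyl: An Expected Value

This account rests on a few compounds, and the source may have more. Where it says the series, first, only, none or still open, it means among the compounds named here.

Of the compounds shown here, three sharing one core have been measured in an assay on isolated protein for displacement of a labelled ligand from melanin-concentrating hormone receptor 1 (Homo sapiens); on this read-out higher numbers stand for weaker inhibition and lower numbers for stronger inhibition. Compound 1 `CCCc1cc(N)c2cc(NC(=O)/C=C/c3ccc(Br)cc3)ccc2n1` gives 4 nM in this assay. Compound 2 `CCCc1cc(N)c2cc(NC(=O)c3ccc(-c4ccc(Cl)cc4)cc3)ccc2n1` gives 0.7 nM, and compound 3 `CCCc1cc(N(C)C)c2cc(NC(=O)/C=C/c3ccc(C(F)(F)F)cc3)ccc2n1` gives 43 nM. Among these three numbers compound 1 stands second highest; its nearest neighbour is compound 2, whose number is lower by a margin beyond the scatter, and its furthest is compound 3, whose number is higher, again beyond the scatter.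

Compound 4 `CCCc1cc(N)c2cc(NC(=O)/C=C/c3ccc(Cl)cc3Cl)ccc2n1` has not yet been measured in this assay. It differs from compound 1 in one place: 2,4-dichlorophenyl in place of 4-bromophenyl on a double-bonded chain carbon bound to a double-bonded chain carbon. Going by the values given here, no two measured compounds differ in this way, so no measured step gives the size of the change. Both the leaving and the entering group are one six-membered aromatic ring of carbon only, with no hydrogen-bond donors or acceptors, so only a small step is expected, likely a slight rise in the number, within or just beyond the scatter. Compound 4 is therefore expected to give about 6 nM in this assay, with a range from 1.5 nM to 20 nM. The expected step is a 1.5-fold higher number from compound 1 to compound 4 (0.18 log units; within the scatter).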

Compound 4, half-maximal inhibitory concentration: 6.6 nM
Compound 4: middle estimate off by 1.1-fold (0.04 log units), on the low side; the range from low to high includes it.
By their numbers in this assay, from the lowest: compound 2; then compounds 1 and 4 (each within the scatter of the next); then compound 3.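

In this assay, 2,4-dichlorophenyl in place of 4-bromophenyl on a double-bonded chain carbon bound to a double-bonded chain carbon comes with a 1.7-fold higher number from compound 1 to compound 4 (0.22 log units; within the scatter), the first step measured at this position. For this one pair, then, two chlorine atoms can stand in place of one bromine on the six-membered aromatic ring without a step beyond the scatter. No measured property of either group accompanies this pair, so the data offer no explanation of the step.

The compounds shown leave open how each chlorine contributes, which 4-chlorophenyl and 2-chlorophenyl at this place on the core of compound 1 would separate. They also leave open whether the same place would accept a phenyl ring carrying a carboxylic acid or an amine, and how far the number would then move.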